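Two Methoxy Groups in Place of One Chloro

This account rests on a few compounds, and the source may have more. Where it says the series, first, only, none or still open, it means among the compounds named here.

In a functional assay on U-87MG ATCC cells for antiproliferative activity against U-87 MG (Homo sapiens), read by MTT assay, with a stated time of 48 h, tested at 50 uM (on this read-out lower numbers stand for a stronger effect and higher numbers for a weaker effect at the one concentration tested), compound 3 `Cc1nc(-c2ccccc2)sc1C(=O)CSc1nc(-c2cccc(Cl)c2)c(C#N)c(=O)[nH]1` gives 50.6%, the lowest of the three numbers: compound 2 `Cc1nc(-c2ccccc2)sc1C(=O)CSc1nc(-c2ccc(Cl)c(Cl)c2)c(C#N)c(=O)[nH]1` gives 75.3% and compound 1 `COc1cccc(-c2nc(SCC(=O)c3sc(-c4ccccc4)nc3C)[nH]c(=O)c2C#N)c1` gives 80.3%. Compound 4 `COc1ccc(-c2nc(SCC(=O)c3sc(-c4ccccc4)nc3C)[nH]c(=O)c2C#N)cc1OC` differs from compound 3 by 3,4-dimethoxyphenyl in place of 3-chlorophenyl on an aromatic carbon. Going by the values given here, two measured steps bear on this change. First, a number 29.7 percentage points lower from compound 1 to compound 3 (beyond the scatter), so returning a methoxy in place of the chloro should raise the number by about that much. Second, a number 24.7 percentage points lower from compound 2 to compound 3 (beyond the scatter), so a group entering where compound 3 carries hydrogen should raise it again. Both point the same way, so a step of a number 34.4 percentage points higher from compound 3 to compound 4 (beyond the scatter) in this assay is expected, toward a weaker effect. Compound 4 is therefore estimated at 85%, between 65% and 100%.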

Compound 4, a percentage reported as activity, at one concentration (the size of the read-out at that concentration, not a potency): 21.4%
The estimate for compound 4 lay 63.6 percentage points above the measured number, and the stated range ends above it.
By their numbers in this assay, from the lowest: compound 4; then compound 3; then compounds 2 and 1 (each within the scatter of the next).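

At this position, 3,4-dimethoxyphenyl in place of 3-chlorophenyl gives a number 29.2 percentage points lower from compound 3 to compound 4 (beyond the scatter) in this assay, so a methoxy here does not go with a weaker effect in every compound. A second methoxy on the ring of compound 1 gives a number 58.9 percentage points lower from compound 1 to compound 4 (beyond the scatter), and methoxy groups in place of both chloro groups give a number 53.9 percentage points lower from compound 2 to compound 4 (beyond the scatter), so a single substituent's step did not carry over to the two-substituent ring. No measurement offered here explains this reversal. On these data alone, whether an amine or a carboxylic acid on this ring would extend the trend remains open.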